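A smaller amine on the shared core

The source may report more compounds than this note shows. Statements on the series, on what has been measured and on what is new or still open speak of the compounds shown alone.

Compound 1 `CCCCCN(CCCCC)c1nc2c(ncn2-c2ccccc2)c(=O)n1-c1ccc(Cl)cc1`: 10600 nM
Compound 2 `CNc1nc2c(ncn2-c2ccccc2)c(=O)n1-c1ccccc1`: > 100000 nM

Within the data shown here, in a functional assay on KB cells (Homo sapiens) for cytotoxicity, read by MTT assay, with a stated time of 72 h (a higher number here means a weaker inhibitor, a lower number a stronger inhibitor), compound 1 gives 10600 nM, the only actual number among the two values shown. Compound 2 sits at the limit of > 100000 nM in this assay, at which 1 of the 2 values shown sits, a limit of the assay rather than a number. Compound 3 `CCCCNc1nc2c(ncn2-c2ccccc2)c(=O)n1-c1ccc(Cl)cc1` differs from compound 1 by butylamino in place of dipentylamino on an aromatic carbon. Among the measured compounds shown here, no step between measured compounds covers this change, and compound 2 differs from compound 3 in two places, so it offers no direct guide. The step is expected to weaken inhibition beyond the scatter, a 3.8-fold higher number from compound 1 to compound 3 (0.58 log units; beyond the scatter). Compound 3 is therefore estimated at 40000 nM, likely between 8000 nM and 200000 nM.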

Compound 3, half-maximal inhibitory concentration: 37700 nM
Beside the measured number, compound 3's estimate is 1.1-fold (0.03 log units) above it; low and high end bracket the measured number.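

In this assay, exchanging dipentylamino for butylamino on the aromatic carbon between two ring nitrogen atoms, a change that also brings in a hydrogen-bond donor, gives a 3.6-fold higher number from compound 1 to compound 3 (0.55 log units; beyond the scatter). Among these compounds, this is the first direct reading at this position, and the step is modest: compound 3, with its single shorter chain, still gives an actual number rather than a limit. Nothing shown gives a reason for this step.

Among the compounds shown here, the single step does not separate the loss of one chain from the shortening of the other or the added donor. As far as these compounds go, a dibutylamino or pentylamino group would separate them, and a cyclic amine such as piperidine remains open too.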